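The source may report more compounds than this note shows. Statements on the series, on what has been measured and on what is new or still open speak of the compounds shown alone.

Measured so far in a functional assay on SK-OV-3 cells (Homo sapiens) for antiproliferative activity, read by MTT assay, with a stated time of 72 h; a lower number here means a stronger inhibitor, a higher number a weaker inhibitor:
- compound 1 `O=C(CCc1cccc2c1B(O)OC2)Nc1ccccc1`: 200 nM
- compound 2 `O=C(CCc1cccc2c1B(O)OC2)Nc1cccc(Br)c1`: 540 nM
- compound 3 `O=C(CCc1cccc2c1B(O)OC2)Nc1cccc(I)c1`: 630 nM

Compound 3, at 630 nM, stands with the upper pair of these numbers. The gap to its nearest neighbour is small, a 1.2-fold higher number from compound 2 to compound 3 (0.07 log units; within the scatter), while compound 1 lies further off, a 3.2-fold higher number from compound 1 to compound 3 (0.50 log units; beyond the scatter).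

Compound 4 `CC(C)c1cccc(NC(=O)CCc2cccc3c2B(O)OC3)c1` changes the same aromatic carbon: isopropyl in place of iodo on an aromatic carbon. For the measured compounds named here, no measured step involves isopropyl, so the evidence is indirect. Placing a halogen on the unsubstituted ring gave modest rises, a 2.7-fold higher number from compound 1 to compound 2 (0.43 log units; beyond the scatter) and a 3.2-fold higher number from compound 1 to compound 3 (0.50 log units; beyond the scatter), and exchanging one halogen for the other changed little, a 1.2-fold higher number from compound 2 to compound 3 (0.07 log units; within the scatter). In this assay, a swap between these larger groups is therefore expected to give no step beyond the scatter. For compound 4 the expected step is a 1.1-fold lower number from compound 3 to compound 4 (0.02 log units; within the scatter). Compound 4 is estimated at 600 nM, within an expected range of 250 nM to 1400 nM.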

Compound 4, half-maximal inhibitory concentration: 510 nM
Estimate against measurement, compound 4: 1.2-fold (0.07 log units) above; low and high end bracket the measured number.
By their numbers in this assay, from the lowest: compound 1; then compounds 4, 2 and 3 (each within the scatter of the next).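

In this assay, isopropyl, with three carbon heavy atoms in place of a single iodine, falls in with the halogens at this aromatic carbon: a 1.2-fold lower number from compound 3 to compound 4 (0.09 log units; within the scatter) and a 1.1-fold lower number from compound 2 to compound 4 (0.02 log units; within the scatter). Set against the unsubstituted compound 1, it gives a modest step of the same kind as bromo and iodo, a 2.6-fold higher number from compound 1 to compound 4 (0.41 log units; beyond the scatter), so that compound 2, compound 3 and compound 4 cannot be told apart, while each has a higher number than compound 1 beyond the scatter. Nothing available bears on why a non-halogen group gives such a result here.

From the compounds shown here alone, it remains open whether an amine or a carboxylic acid on this carbon would join these three compounds or move away from them. Going by these compounds, a longer chain, such as hexyl, is equally open.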